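Isopropyl in Place of Chloro: Solubility of Compound 4

A few compounds are considered here, and "the series" means these few. Any claim that something is new, unique, unknown or untested is made for them only; others in the source may bear on it.

Compound 1 `CNC(=O)c1cc(Oc2ccc3nc(Nc4cccc(C(C)(C)C)c4)cnc3c2)ccn1` gives < 1000 nM in a physicochemical assay for solubility, at pH 7 (a higher number here means a more soluble compound, a lower number a less soluble compound), a limit of the assay.
Compound 2 `CNC(=O)c1cc(Oc2ccc3nc(Nc4ccccc4Oc4ccccc4)ncc3c2)ccn1` gives < 1000 nM, also a limit.
Compound 3 `CNC(=O)c1cc(Oc2ccc3nc(Nc4cccc(Cl)c4)ncc3c2)ccn1` gives < 1000 nM, again a limit.

Compound 3 therefore stands only at a limit in this assay, and the same holds for every measured compound (the limit of < 1000 nM in this assay, at which 3 of the 3 values shown sit). For the measured compounds named here, no step between measured compounds can be drawn from such values. Compound 4 `CNC(=O)c1cc(Oc2ccc3nc(Nc4cccc(C(C)C)c4)ncc3c2)ccn1` differs from compound 3 by isopropyl in place of chloro on an aromatic carbon. With nothing measured to lean on, no shift beyond the scatter is expected. Compound 4 is expected at 500 nM, between 150 nM and 1500 nM, and most likely reported once more only as a limit. The step from compound 3 to compound 4 is expected as a step that the limit leaves unreadable from compound 3 to compound 4.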

Compound 4, solubility: < 1000 nM
Compound 4 gave a limit, no number; the forecaster's own chance of this, stated with the estimate: 80%; the middle value does not contradict the limit.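

For the compounds shown here, compound 3 and compound 4 both stand only at a limit, so no step between them can be read: the limit of < 1000 nM in this assay, at which 4 of the 4 values shown sit. The compounds shown leave open what number any of them would give, and whether isopropyl in place of chloro shifts it.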